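A few compounds are considered here, and "the series" means these few. Any claim that something is new, unique, unknown or untested is made for them only; others in the source may bear on it.

In a functional assay on MCF7 cells (Homo sapiens) for inhibition, read by sulforhodamine B assay (a lower number here means a stronger inhibitor, a higher number a weaker inhibitor), compound 3 `CCOc1ccccc1NC1=CC(=O)c2nc3n(c2C1=O)[C@H]1OC[C@@H](O)[C@H]1OC3` gives > 4000 nM, which is a limit of the assay and not a number. Compound 1 `COc1ccccc1NC1=CC(=O)c2nc3n(c2C1=O)[C@H]1OC[C@@H](O)[C@H]1OC3` gives > 4000 nM, also only a limit. Compound 2 `CCOc1ccc(NC2=CC(=O)c3nc4n(c3C2=O)[C@H]2OC[C@@H](O)[C@H]2OC4)cc1` gives a true number, 1430 nM. Compound 4 `O=C1C=C(Nc2cccc(Cl)c2)C(=O)c2c1nc1n2[C@H]2OC[C@@H](O)[C@H]2OC1` has 3-chlorophenyl in place of 2-ethoxyphenyl on an amine nitrogen. For the measured compounds named here, no measured compound carries 3-chlorophenyl, so the guidance is indirect. Going by the values given here, two steps bear on the change: an at least 2.7-fold lower number from compound 1 to compound 2 (0.44 log units; beyond the scatter) and an at least 2.7-fold higher number from compound 2 to compound 3 (0.44 log units; beyond the scatter). Compound 4 gives up the 2-ethoxyphenyl group of compound 3, so a modest drop in the number is expected, though it may stay at the limit. The expected step is an at least 2.2-fold lower number from compound 3 to compound 4 (0.34 log units; beyond the scatter). For compound 4 the estimated value is 1800 nM, with an expected range of 700 nM to 4000 nM.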

Compound 4, half-maximal inhibitory concentration: 4720 nM
The estimate for compound 4 lay 2.6-fold (0.42 log units) below the measured number; measured number outside the range, above it.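

Putting 3-chlorophenyl in place of 4-ethoxyphenyl on the amine nitrogen gives a 3.3-fold higher number from compound 2 to compound 4 (0.52 log units; beyond the scatter), so this change weakens inhibition. Compound 2 remains the strongest inhibitor of the four, and a group without an oxygen on the phenyl ring has not matched it here. The steps from compound 4 to compound 1 and compound 3 cannot be read because those two compounds have only a limit: the limit of > 4000 nM in this assay, at which 2 of the 4 values shown sit.

As far as these compounds go, how a longer chain such as butoxy, or a carboxylic acid, on the phenyl ring would compare with compound 2 remains open.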